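From phenyl to pyridin-4-yl on the shared core

The source may report more compounds than this note shows. Statements on the series, on what has been measured and on what is new or still open speak of the compounds shown alone.

Of the compounds shown here, two have been measured so far in a functional assay on HCT-116 cells (Homo sapiens) for antiproliferative activity, read by MTT assay, with a stated time of 48 h; a higher number here means a weaker inhibitor, a lower number a stronger inhibitor. Compound 1 `CCCc1nc2cc(C(=O)N3CCC4(CC3)CC(=O)N(c3ccc(C(F)(F)F)cc3)C4)cc(C)c2[nH]1` gives 4210 nM, while compound 2 `O=C(c1ccc2[nH]c(-c3ccccc3)nc2c1)N1CCC2(CC1)CC(=O)N(c1ccc(C(F)(F)F)cc1)C2` gives 1220 nM. Compound 2 therefore holds the lower of the two numbers, by a margin beyond the usual scatter. These two compounds differ in more than one place, so their gap cannot be tied to any single group.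

Compound 3 `O=C(c1ccc2[nH]c(-c3ccncc3)nc2c1)N1CCC2(CC1)CC(=O)N(c1ccc(C(F)(F)F)cc1)C2` has pyridin-4-yl in place of phenyl on an aromatic carbon, between two ring nitrogen atoms, and is otherwise the same as compound 2: pyridin-4-yl in place of phenyl on an aromatic carbon. Going by the values given here, no measured pair shows this exchange, so the only anchor is compound 2 at 1220 nM. The expected change, a 1.2-fold lower number from compound 2 to compound 3 (0.09 log units; within the scatter), is estimated to stay within the scatter, with no firm direction. For compound 3 the estimated value is 1000 nM, with an expected range of 300 nM to 3500 nM.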

Compound 3, half-maximal inhibitory concentration: 7640 nM
For compound 3 the middle estimate is 7.6-fold (0.88 log units) below the measured one; the measured number lies above the stated range.
By their numbers in this assay, from the lowest: compound 2; then compounds 1 and 3 (each within the scatter of the next).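

In this assay, going by these compounds alone, the exchange of phenyl for pyridin-4-yl on an aromatic carbon, between two ring nitrogen atoms, gives a 6.3-fold higher number from compound 2 to compound 3 (0.80 log units; beyond the scatter) and is the first change at this place that can be read alone, since the earlier compounds differ in more than one place. The two groups have the same count of heavy atoms and differ by one ring nitrogen and one hydrogen-bond acceptor, so in this single pair an exchange of one ring atom is enough for a step beyond the scatter. Nothing measured here accounts for this step.

From the compounds shown here alone, what pyridin-3-yl or a phenyl bearing an amine would give at this place remains open. Also open, going by these compounds, is whether the exchange gives a step of this size when chloro replaces trifluoromethyl elsewhere on the shared core.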